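Compound 1 to compound 4: adding 3-aminopropyl

The compounds below may be only part of what the source reports. "The series", "measured", "known", "first", "only" and "open" are said of these compounds alone.

In a functional assay on DU-145 cells (Homo sapiens) for antiproliferative activity, read by MTT assay, with a stated time of 48 h (a lower number here means a stronger inhibitor, a higher number a weaker inhibitor), compound 1 `COc1cc(C(=O)/C=C/c2ccc(OCCCC(=O)NCCCCN(CCCN)CCCCN)cc2)cc(OC)c1OC` gives 86800 nM, the higher of the two actual numbers in the series. Compound 3 `COc1cc(C(=O)/C=C/c2ccc(OCCCC(=O)NCCCNCCCCNCCN)cc2)cc(OC)c1OC` gives 35400 nM, and the distance is a 2.5-fold lower number from compound 1 to compound 3 (0.39 log units; beyond the scatter). In this assay compound 2 `COc1cc(C(=O)/C=C/c2ccc(OCCCC(=O)NCCCNCCCCN)cc2)cc(OC)c1OC` gives only a limit, > 100000 nM. Against that limit, an at least 1.1-fold higher number from compound 1 to compound 2 (0.06 log units; that floor lies within the scatter) sets a floor and no more, so that step says little.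

The next structure is compound 4 `COc1cc(C(=O)/C=C/c2ccc(OCCCC(=O)NCCCCN(CCCN)CCCCNCCCN)cc2)cc(OC)c1OC`. Its change from compound 1 is 3-aminopropyl in place of hydrogen on an amine nitrogen.

The closest measured precedent is an at least 2.8-fold lower number from compound 2 to compound 3 (0.45 log units; beyond the scatter), where 2-aminoethyl takes the place of hydrogen on an amine nitrogen. This is one step on a different parent and a different group, so it supports direction more firmly than size. The step to compound 3 from compound 1 is of similar size, but it rearranges more of the chain and bears less directly.

A modest fall in the number is therefore expected in this assay, with no change beyond the scatter remaining possible. The estimated step is a 2.2-fold lower number from compound 1 to compound 4 (0.34 log units; beyond the scatter). For compound 4 the expected value is 40000 nM, with an estimated range of 15000 nM to 100000 nM.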

Compound 4, half-maximal inhibitory concentration: 92500 nM
The estimate for compound 4 lay 2.3-fold (0.36 log units) below the measured number; low and high end bracket the measured number.
By their numbers in this assay, from the lowest: compound 3; then compounds 1 and 4 (each within the scatter of the next). At a limit, above all of these: compound 2.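

In this assay, a 1.1-fold higher number from compound 1 to compound 4 (0.03 log units; within the scatter), so on this parent 3-aminopropyl in place of hydrogen on an amine nitrogen gives no change beyond the scatter. The earlier addition on an amine nitrogen, an at least 2.8-fold lower number from compound 2 to compound 3 (0.45 log units; beyond the scatter), involved 2-aminoethyl on a different parent, and its direction does not carry over here: among the compounds shown, adding an aminoalkyl group on an amine nitrogen is no general route to a lower number, with compound 3 the one case against. Among steps between two actual numbers, the only one beyond the scatter remains a 2.5-fold lower number from compound 1 to compound 3 (0.39 log units; beyond the scatter), a step that rearranges the chain and does not simply extend it.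

As far as these compounds go, compound 2 gives a limit and not a number, so the true size of its steps stays open: the limit of > 100000 nM in this assay, at which 1 of the 4 values shown sits. Also open, from the compounds shown here alone, is whether this flat result on the amine nitrogen of compound 1 holds for other groups in place of 3-aminopropyl, such as a longer chain with a terminal amine or a chain ending in a carboxylic acid.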